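Swapping Methyl for Chloro: What Compound 4 May Give

This account rests on a few compounds, and the source may have more. Where it says the series, first, only, none or still open, it means among the compounds named here.

Compound 1 `Cc1cc(-n2cc(C(=O)Nc3cc(F)cc(F)c3)c(=O)c3ccc(N(C)C)nc32)ccc1OCCCCCCC[N+]1(C)CCCC1`, compound 2 `CN(C)c1ccc2c(=O)c(C(=O)Nc3cc(F)cc(F)c3)cn(-c3ccc(OCCCCCCC[N+]4(C)CCCC4)c(Cl)c3)c2n1` and compound 3 `Cc1ccc(-n2cc(C(=O)Nc3cc(F)cc(F)c3)c(=O)c3ccc(N(C)C)nc32)cc1OCCCCCCC[N+]1(C)CCCCC1` have been measured in an assay on LX2 cells for inhibition of COL1A1 promoter (Homo sapiens), read by a luciferase reporter, with a stated time of 24 h, tested at 50 uM; a higher number here means a stronger effect of the compound at the concentration tested, a lower number a weaker effect; compound 4 `CN(C)c1ccc2c(=O)c(C(=O)Nc3cc(F)cc(F)c3)cn(-c3ccc(Cl)c(OCCCCCCC[N+]4(C)CCCCC4)c3)c2n1` has not. In this assay compound 1 gives 35.9%, compound 2 gives 2.59% and compound 3 gives 45.1%. Compound 1 and compound 3 share much of their structure, but the difference between the two cores is not broken down here; their two numbers lie within the usual scatter of each other. The step of a number 33.3 percentage points lower from compound 1 to compound 2 (beyond the scatter) goes with the change (chloro in place of methyl on an aromatic carbon). Compound 4 arises from compound 3 by the same kind of change, (chloro in place of methyl on an aromatic carbon); what differs around the place is that the chloro sits meta to a large group in compound 2 but para to a large group in compound 4. Because the same kind of swap gave the step of a number 33.3 percentage points lower from compound 1 to compound 2 (beyond the scatter), compound 4 is expected to lose activity by a step of similar size, estimated as a number 30.1 percentage points lower from compound 3 to compound 4 (beyond the scatter). Compound 4 is therefore estimated at 15%, with a likely range from 0% to 35%.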

Compound 4, a percentage reported as inhibition, at one concentration (the size of the read-out at that concentration, not a potency): 90.5%
Beside the measured number, compound 4's estimate is 75.5 percentage points below it, and the stated range ends below it.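

In this assay, chloro in place of methyl on an aromatic carbon gives a number 45.4 percentage points higher from compound 3 to compound 4 (beyond the scatter), the opposite direction to the earlier step. The effect of this swap therefore does not carry over as a fixed gain or loss from one core to the other, and even its direction depends on the compound that receives it: the same change on two cores in this assay, a number 33.3 percentage points lower (beyond the scatter) from compound 1 to compound 2 and a number 45.4 percentage points higher (beyond the scatter) from compound 3 to compound 4, 78.7 percentage points apart, beyond the scatter of two such steps. This does not show why the direction reverses, as the two pairs differ from each other in more than one place, and two pairs cannot reveal a general rule for the series.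

From the compounds shown here alone, it remains open whether a fluoro, bromo or methoxy group at the same place would follow the rise seen in the pair of compound 3 and compound 4 or the fall seen in the pair of compound 1 and compound 2. A shorter chain in place of the long chain carrying the charged ring could also alter the size of either step, and a single tested concentration gives no potency for any of these compounds.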